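Swapping halogens on an allyl-bearing analogue

A few compounds are considered here, and "the series" means these few. Any claim that something is new, unique, unknown or untested is made for them only; others in the source may bear on it.

Measured so far:
compound 1, `COc1ccccc1/C=c1\c(=O)[nH]/c(=C/c2cccc(Cl)c2Cl)c(=O)n1C`: 100 nM
compound 2, `C=CCn1c(=O)/c(=C\c2ccc(F)c(Br)c2)[nH]c(=O)/c1=C\c1ccccc1OC`: "not active" (no number reported)
compound 3, `COc1ccccc1/C=c1/[nH]c(=O)/c(=C\c2nc[nH]c2C(C)(C)C)[nH]c1=O`: 50 nM

In a functional assay on U-937 cells (Homo sapiens) for cytotoxicity, read by CCK-8 assay, with a stated time of 72 h (a higher number here means a weaker inhibitor, a lower number a stronger inhibitor), compound 1 gives 100 nM and compound 3 gives 50 nM, and these two values lie within the usual scatter of one another. Among the compounds with values here, compound 2 is the odd one out: in this assay compound 2 is reported as "not active" (no number reported), so it has no number to set beside the other two, and no step between any of these three compounds can be sized from the data.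

Compound 4, `C=CCn1c(=O)/c(=C\c2ccc(Cl)c(Cl)c2)[nH]c(=O)/c1=C\c1ccccc1OC`, is the untested one. It keeps the allyl group on the ring nitrogen and the methoxyphenyl arm of compound 2, and differs from it only by 3,4-dichlorophenyl in place of 3-bromo-4-fluorophenyl on a double-bonded chain carbon bound to an aromatic carbon. Compound 1 also carries a dichlorophenyl arm, but on a different core substitution, so it does not tell directly what this swap does here.

Because compound 2 stands at "not active" (no number reported) with no number, the size of the step to compound 4 cannot be stated; the expectation is for compound 4 to stay weak, with a fair chance that this assay again reports no number for it. Compound 4 is estimated at 5000 nM, within a range of 500 nM to 50000 nM.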

Compound 4, half-maximal inhibitory concentration: "not active" (no number reported)
Nothing numeric was reported for compound 4; there is nothing to compare the estimate with.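

In this assay, within the data shown here, compound 2 gives "not active" (no number reported) and compound 4 gives "not active" (no number reported), so no step between these two compounds can be read. No evidence bears on this result. The compounds shown leave open whether 3,4-dichlorophenyl in place of 3-bromo-4-fluorophenyl changes the activity at all in this assay.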